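Taking away the hydroxy: what to expect for compound 4

The source may hold more compounds than are shown below. What is called first, only, known or untested is meant among the compounds shown, and "the series" means these compounds.

Values measured in an in vitro ADME assay on microsomes from liver (Homo sapiens) for metabolic stability (on this read-out lower numbers stand for slow clearance and higher numbers for fast clearance), for three compounds:
- compound 1 `COc1cccc(C(=O)N2CCC(=CC(=O)N[C@@H]3CCN(Cc4ccc5cc(F)ccc5c4)C3)CC2)c1` gives 500 mL/min/kg
- compound 2 `COc1ccc(O)c(C(=O)N2CCC(=CC(=O)N[C@@H]3CCN(Cc4ccc5cc(F)ccc5c4)C3)CC2)c1` gives 119 mL/min/kg
- compound 3 `COc1cccc(C(=O)N2CCC(=CC(=O)N[C@@H]3CCN(Cc4ccc5cc(F)ccc5c4)C3)CC2)c1O` gives 162 mL/min/kg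

Compound 3 stands at 162 mL/min/kg in this small set, clearly under compound 1 and not distinguishable from compound 2. The two hydroxy compounds differ little, and a 1.4-fold higher number from compound 2 to compound 3 (0.13 log units; within the scatter) is the whole gap between them.

The next structure is compound 4 `COc1ccc(C(=O)N2CCC(=CC(=O)N[C@@H]3CCN(Cc4ccc5cc(F)ccc5c4)C3)CC2)cc1OC` and the change is this: 3,4-dimethoxyphenyl in place of 2-hydroxy-3-methoxyphenyl on a carbonyl carbon. In words, 3,4-dimethoxyphenyl replaces 2-hydroxy-3-methoxyphenyl on a carbonyl carbon, so the hydroxy leaves and a second methoxy enters.

For the measured compounds named here, the steps that bear on this are the two that added a hydroxy: a 4.2-fold lower number from compound 1 to compound 2 (0.62 log units; beyond the scatter) and a 3.1-fold lower number from compound 1 to compound 3 (0.49 log units; beyond the scatter) are both modest but real. Neither hydroxy compound goes against this pattern, though it rests on three compounds only. Going by the values given here, no measured step shows what a second methoxy does. Compound 1, which also has no hydroxy, gives 500 mL/min/kg and is the nearest guide.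

In this assay an upward step of similar size is therefore expected, and the estimate is a 2.2-fold higher number from compound 3 to compound 4 (0.33 log units; beyond the scatter) as a result. Compound 4 is expected at 350 mL/min/kg with an estimated range from 150 mL/min/kg to 700 mL/min/kg as the likely span.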

Compound 4, clearance: 246 mL/min/kg
The estimate for compound 4 lay 1.4-fold (0.15 log units) above the measured number; the measured number falls inside the stated range.
By their numbers in this assay, from the lowest: compounds 2, 3 and 4 (each within the scatter of the next, the first and the last beyond it); then compound 1.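

In this assay a second methoxy on the ring gives a 2.0-fold lower number from compound 1 to compound 4 (0.31 log units; beyond the scatter) and so shows that the number can fall with no hydroxy on the ring at all. Among the three compounds with a second group on the ring, none goes against this picture of lying under compound 1, so a hydroxy is not required for a real step down from it. The hydroxy compounds also no longer stand apart as a pair, since 3,4-dimethoxyphenyl in place of 2-hydroxy-3-methoxyphenyl gives a 1.5-fold higher number from compound 3 to compound 4 (0.18 log units; within the scatter) while 3,4-dimethoxyphenyl in place of 2-hydroxy-5-methoxyphenyl gives a 2.1-fold higher number from compound 2 to compound 4 (0.32 log units; beyond the scatter) and thus separates compound 4 from only one of the two.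

Nothing available explains why any of these steps takes the size it does. Going by these compounds, it also remains open whether a second group of another kind on the same ring, such as a fluorine, an amine or a carboxylic acid, would bring the number down from that of compound 1 in the same way as a methoxy or a hydroxy.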